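The compounds below may be only part of what the source reports. "The series", "measured", "known", "first", "only" and "open" are said of these compounds alone.

Measured compounds:
Compound 1, `C/C(=N/NC(=S)Nc1ccccc1)c1ccccn1`: 6.81 nM
Compound 2, `CC(=NNC(=S)Nc1cccc(I)c1)c1ccccn1`: 61 nM
Compound 3, `CC(=NNC(=S)Nc1ccccc1)c1ccccn1`: 6.8 nM

In a functional assay on T98G cells (Homo sapiens) for cytotoxicity, read by MTT assay, with a stated time of 48 h (a higher number here means a weaker inhibitor, a lower number a stronger inhibitor), compound 1 gives 6.81 nM and compound 3 gives 6.8 nM. The two share all atoms and bonds, differing only in how they are drawn: the two compounds have the same atoms and bonds; at least one stereo element is drawn with a configuration in one of them and without one in the other: 1 of 1 stereo elements differ; a double bond is drawn without a configuration in compound 3 and Z in compound 1. The step of a 1.0-fold lower number from compound 1 to compound 3 (0.00 log units; within the scatter) is within the scatter, which fits with the fact that one of compounds 1 and 3 is drawn with a defined configuration and the other without, at the place where they differ.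

Compound 2 carries one change against compound 3: iodo in place of hydrogen on an aromatic carbon. This change gives a 9.0-fold higher number from compound 3 to compound 2 (0.95 log units; beyond the scatter), a modest weakening.

Compound 4, `C/C(=N/NC(=S)Nc1ccccc1I)c1ccccn1`, has not yet been measured in this assay. Against compound 1 the difference is iodo in place of hydrogen on an aromatic carbon. Among the measured compounds shown here, this is the same kind of change as the one from compound 3 to compound 2, but not the same: in compound 2 the iodo sits meta to a large group, whereas in compound 4 it sits ortho to a large group.

For the measured compounds named here, compound 4 is expected to show a step of a 6.6-fold higher number from compound 1 to compound 4 (0.82 log units; beyond the scatter) from compound 1, since the only measured example of this kind of change, a 9.0-fold higher number from compound 3 to compound 2 (0.95 log units; beyond the scatter), weakened inhibition, and the difference in place adds uncertainty. Compound 4 is therefore estimated at 45 nM, between 10 nM and 200 nM.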

Compound 4, half-maximal inhibitory concentration: 8.09 nM
Compound 4: middle estimate off by 5.6-fold (0.75 log units), on the high side, outside the stated range (below it).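

In this assay, iodo in place of hydrogen on an aromatic carbon gives a 1.2-fold higher number from compound 1 to compound 4 (0.07 log units; within the scatter), which does not match the earlier step of the same kind: the same change on two cores in this assay, a 9.0-fold higher number (0.95 log units; beyond the scatter) from compound 3 to compound 2 and a 1.2-fold higher number (0.07 log units; within the scatter) from compound 1 to compound 4, 7.6-fold (0.88 log units) apart, beyond the scatter of two such steps. The weakening seen in compound 2 therefore does not carry over to compound 4 as a fixed step, and the size of this change cannot simply be transferred from one core to another in this series. This does not show what separates the two steps: the iodo in compound 4 is ortho to a large group and the iodo in compound 2 stands elsewhere on the ring, and one pair for each place cannot establish a rule for either.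

The compounds shown leave open whether chloro or fluoro at the place taken by iodo in compound 4 would also stay close to compound 1. They also leave open how a methoxy group, an amine or a carboxylic acid on the same ring would read in this assay.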